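A Pyridine-to-Fluorophenyl Swap on a Shared Core

This account rests on a few compounds, and the source may have more. Where it says the series, first, only, none or still open, it means among the compounds named here.

Compound 1 `O=C(/C=C/c1ccc2c(c1)B(O)OC2)c1cccnc1` and compound 2 `CCOC(=O)c1ccc(C(=O)/C=C/c2ccc3c(c2)B(O)OC3)cc1` share the same core and differ only in the aromatic group attached to the carbonyl carbon. For the measured compounds named here, in a functional assay on HCT-116 cells (Homo sapiens) for cytotoxicity, read by MTT assay, with a stated time of 48 h (a lower number here means a stronger inhibitor, a higher number a weaker inhibitor), compound 1 gives 20500 nM, the higher of the two numbers known here, while compound 2 gives 7600 nM, a gap that lies beyond the usual scatter of this measurement.

Compound 3 `O=C(/C=C/c1ccc2c(c1)B(O)OC2)c1ccccc1F` is a fresh variant of compound 1. The change is 2-fluorophenyl in place of pyridin-3-yl on a carbonyl carbon. Going by the values given here, only two measured compounds are known and no single-point step between them has been worked out, so there is no directly comparable change to lean on. The one firm point is that compound 1, at 20500 nM, is a weak inhibitor in this assay.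

The expected step is a 1.7-fold lower number from compound 1 to compound 3 (0.23 log units; within the scatter), a modest move toward a lower number that may not clear the scatter. Compound 3 is therefore estimated at 12000 nM, with a likely range from 4000 nM to 36000 nM.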

Compound 3, half-maximal inhibitory concentration: 4200 nM
Estimate against measurement, compound 3: 2.9-fold (0.46 log units) above; low and high end bracket the measured number.
By their numbers in this assay, from the lowest: compounds 3 and 2 (each within the scatter of the next); then compound 1.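

In this assay, for the compounds shown here, the group on the carbonyl carbon proves able to shift the number, since 2-fluorophenyl in place of pyridin-3-yl gives a 4.9-fold lower number from compound 1 to compound 3 (0.69 log units; beyond the scatter) and this is the first single-change step known at this place. Compound 3 gives 4200 nM and compound 2 gives 7600 nM and these two numbers lie within the scatter of each other, so among these three compounds only compound 1, with its pyridin-3-yl group, stands apart. No measured evidence comes with these numbers to account for the step.

The swap removes a nitrogen and adds a fluorine in one move, so the compounds shown leave open which of the two matters, or whether both do. A plain phenyl group on the carbonyl carbon would split the change into those two parts, and a chlorophenyl group would show whether fluorine itself counts or whether another halogen serves equally well.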